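This account rests on a few compounds, and the source may have more. Where it says the series, first, only, none or still open, it means among the compounds named here.

Among the compounds with values here, compound 1 `CCCCCCc1ccc(-c2ccc(C(=O)N[C@@H](CCCN)C(=O)N[C@H](C(=O)N[C@@H](C)C(=O)N[C@H]3Cc4cn(nn4)CCCN4C[C@@H]5OB(O[C@@H]5C4)[C@H](C)NC3=O)[C@@H](C)O)cc2)cc1` gives 4000 nM in an ADME assay on HepG2 cells (Homo sapiens) for cytotoxicity, with a stated time of 72 h (a lower number here means a stronger inhibitor, a higher number a weaker inhibitor), the second highest of the three numbers measured so far. Compound 2 `CCCCCCc1ccc(-c2ccc(C(=O)N[C@@H](CCCNC(=N)N)C(=O)N[C@H](C(=O)N[C@@H](C)C(=O)N[C@H]3Cc4cn(nn4)CCCN4C[C@@H]5OB(O[C@@H]5C4)[C@H](C)NC3=O)[C@@H](C)O)cc2)cc1` gives 2400 nM, and the step of a 1.7-fold lower number from compound 1 to compound 2 (0.22 log units; within the scatter) sits within the scatter. Compound 3 `CCCCCCc1ccc(-c2ccc(C(=O)N[C@@H](CCCN)C(=O)N(C)[C@H](C(=O)N[C@@H](C)C(=O)N[C@H]3Cc4cn(nn4)CCCN4C[C@@H]5OB(O[C@@H]5C4)[C@H](C)NC3=O)[C@@H](C)O)cc2)cc1` gives 8500 nM, and the step of a 2.1-fold higher number from compound 1 to compound 3 (0.33 log units; beyond the scatter) is modest but beyond the scatter. Compound 4 `CCCCc1ccc(-c2ccc(C(=O)N[C@@H](CCCN)C(=O)N[C@H](C(=O)N[C@@H](C)C(=O)N[C@H]3Cc4cn(nn4)CCCN4C[C@@H]5OB(O[C@@H]5C4)[C@H](C)NC3=O)[C@@H](C)O)cc2)cc1` differs from compound 1 only at the chain on the outer ring: hydrogen in place of ethyl on a saturated chain carbon, four bonds along the chain from an aromatic carbon. Within the data shown here, neither measured step touches this chain; both alter the peptide portion of the shared core, so no measured step bears directly on the new change. Among the measured compounds shown here, with no comparable step in hand, the expectation for compound 4 is a step of a 1.4-fold higher number from compound 1 to compound 4 (0.14 log units; within the scatter), not beyond the scatter. Compound 4 is therefore estimated at 5500 nM, between 2500 nM and 12000 nM.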

Compound 4, half-maximal inhibitory concentration: 29100 nM
The estimate for compound 4 lay 5.3-fold (0.72 log units) below the measured number, outside the stated range (above it).
By their numbers in this assay, from the lowest: compounds 2 and 1 (each within the scatter of the next); then compound 3; then compound 4.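

In this assay, within the data shown here, hydrogen in place of ethyl on a saturated chain carbon, four bonds along the chain from an aromatic carbon, gives a 7.3-fold higher number from compound 1 to compound 4 (0.86 log units; beyond the scatter) and is the largest step so far. Among these compounds, the outer chain, untouched by the earlier steps, therefore influences this read-out, and a shorter chain here raises the number. Nothing shown accounts for the size of this step. Open, as far as these compounds go, is whether a longer chain, or an amine or carboxylic acid at the chain end, moves the number further. Also open, from the compounds shown here alone, is whether the shortening acts the same way alongside the methyl on the amide-type nitrogen of compound 3.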